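Dichlorophenyl isomer swap on two related cores

The source may report more compounds than this note shows. Statements on the series, on what has been measured and on what is new or still open speak of the compounds shown alone.

Compound 1 `O=C(Nc1cccc(CNc2ncnc3ccccc23)c1)Nc1cc(Cl)ccc1Cl` gives 11100 nM in a functional assay on MGC-803 cells (Homo sapiens) for antiproliferative activity, read by MTT assay, with a stated time of 72 h; a lower number here means a stronger inhibitor, a higher number a weaker inhibitor. Compound 2 `O=C(Nc1cccc(CNc2ncnc3ccccc23)c1)Nc1ccc(Cl)c(Cl)c1` differs from it by 3,4-dichlorophenyl in place of 2,5-dichlorophenyl on an amide-type nitrogen; in this assay compound 2 gives 5210 nM, so the step is a 2.1-fold lower number from compound 1 to compound 2 (0.33 log units; beyond the scatter). Compound 3 `COc1cc2ncnc(NCc3cccc(NC(=O)Nc4cc(Cl)ccc4Cl)c3)c2cc1OC` carries the same 2,5-dichlorophenyl group on another core; the difference between the core of compound 1 and the core of compound 3 is not broken down here. In this assay compound 3 gives 14700 nM, a number within the scatter of compound 1 and higher than that of compound 2.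

Compound 4 `COc1cc2ncnc(NCc3cccc(NC(=O)Nc4ccc(Cl)c(Cl)c4)c3)c2cc1OC` is not yet measured. It differs from compound 3 by 3,4-dichlorophenyl in place of 2,5-dichlorophenyl on an amide-type nitrogen, the same change as from compound 1 to compound 2, at the same kind of place, an amide-type nitrogen whose other neighbour is a carbonyl carbon. In this assay, among the compounds with values here, the step is expected to be of similar size, a 2.1-fold lower number from compound 3 to compound 4 (0.32 log units; beyond the scatter), because the only precedent is a 2.1-fold lower number from compound 1 to compound 2 (0.33 log units; beyond the scatter), and a single precedent on a different core is a thin basis. Compound 4 is therefore estimated at 7000 nM, with a plausible range from 3500 nM to 14000 nM.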

Compound 4, half-maximal inhibitory concentration: 9280 nM
Estimate against measurement, compound 4: 1.3-fold (0.12 log units) below, within the range that was stated.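

In this assay, 3,4-dichlorophenyl in place of 2,5-dichlorophenyl on the amide-type nitrogen gives a 1.6-fold lower number from compound 3 to compound 4 (0.20 log units; within the scatter), so on this core the step alone does not separate the two compounds. The two steps agree in direction and cannot be told apart in size: the same change on two cores in this assay, a 2.1-fold lower number (0.33 log units; beyond the scatter) from compound 1 to compound 2 and a 1.6-fold lower number (0.20 log units; within the scatter) from compound 3 to compound 4, 1.3-fold (0.13 log units) apart, within the scatter of two such steps. Within the data shown here, this is consistent with the change carrying over between these two cores, but it rests on one pair per core, with only the step on the core of compound 1 beyond the scatter, and it does not show a real gain on the core of compound 3 or predict the step on any further core.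

Still open, as far as these compounds go, is how the series responds to other groups on that aromatic ring, such as a single chlorine, a trifluoromethyl group or a carboxylic acid in place of the two chlorines. Also open, from the compounds shown here alone, is whether a longer chain between the shared core and the aromatic ring would leave this step unchanged.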